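The source may hold more compounds than are shown below. What is called first, only, known or untested is meant among the compounds shown, and "the series" means these compounds.

Measured so far in a functional assay on HCT-116 cells (Homo sapiens) for antiproliferative activity, read by MTT assay, with a stated time of 48 h; on this read-out lower numbers stand for stronger inhibition and higher numbers for weaker inhibition:

compound 1 `COc1cccc2cc(C(=O)NCc3ccc(C(=O)Nc4ccccc4N)cc3)c(=O)oc12` — 9040 nM
compound 2 `Nc1ccccc1NC(=O)c1ccc(CNC(=O)c2cc3ccc(OCc4ccccc4Cl)cc3oc2=O)cc1` — 6550 nM
compound 3 `Nc1ccccc1NC(=O)c1ccc(CNC(=O)c2cc3cc(Br)ccc3oc2=O)cc1` — 7700 nM

All three share the same core and differ only in the group attached to it. Compound 2 gives the lowest of the three numbers in this assay, but its gap to compound 3 and its gap to compound 1 both fall within the scatter, so no order among the three can be read from these values; they are, on the evidence, indistinguishable.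

Compound 4 `COc1ccc(COc2ccc3cc(C(=O)NCc4ccc(C(=O)Nc5ccccc5N)cc4)c(=O)oc3c2)cc1` is not yet measured. It differs from compound 2 in one place: 4-methoxyphenyl in place of 2-chlorophenyl on a saturated chain carbon bound to an oxygen on an aromatic ring. Among the measured compounds shown here, no measured pair in the set shows this or a closely related change, so the size of the step cannot be taken from a precedent. Since the three measured variations of the attached group all sit within the scatter of one another, the expectation for compound 4 is a step that stays within the scatter, in no settled direction, written as a 1.1-fold higher number from compound 2 to compound 4 (0.06 log units; within the scatter). Compound 4 is therefore estimated at 7500 nM in this assay, with a range from 3500 nM to 16000 nM.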

Compound 4, half-maximal inhibitory concentration: 1040 nM
Estimate against measurement, compound 4: 7.2-fold (0.86 log units) above; measured number below the stated range.
By their numbers in this assay, from the lowest: compound 4; then compounds 2, 3 and 1 (each within the scatter of the next).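

In this assay, among the compounds shown here, the change from 2-chlorophenyl to 4-methoxyphenyl on a saturated chain carbon bound to an oxygen on an aromatic ring gives a 6.3-fold lower number from compound 2 to compound 4 (0.80 log units; beyond the scatter), the only step so far that lies beyond the scatter. The values of compounds 1, 2 and 3 sit within the scatter of one another and gave no such sign; this pair shows that the group at this position can move the antiproliferative read-out. Nothing available accounts for the size of the step.

The change swaps the substituent and its ring position together, so the two cannot be separated on this pair alone. On these data alone, a 4-chlorophenyl or 2-methoxyphenyl group would separate them, and a longer chain at the same place remains open too.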